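Replacing phenylsulfonyl on the amide side chain

The source may report more compounds than this note shows. Statements on the series, on what has been measured and on what is new or still open speak of the compounds shown alone.

Two measured compounds anchor this part of the series. In an in vitro ADME assay on microsomes from liver (Rattus norvegicus) for metabolic stability (on this read-out lower numbers stand for slow clearance and higher numbers for fast clearance), compound 1 (`C[C@@H]1CN(Cc2ccc(-c3ccccc3CN(C)C(=O)COc3ccccc3)cc2)C[C@H](C)N1`) gives 9.5 mL.min-1.g-1 as its read-out. For the measured compounds named here, compound 2 (`C[C@@H]1CN(Cc2ccc(-c3ccccc3CN(C)C(=O)CS(=O)(=O)c3ccccc3)cc2)C[C@H](C)N1`) gives 4.3 mL.min-1.g-1 as the lowest of the two numbers so far.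

Compound 3 (`Cc1cc(CC(=O)N(C)Cc2ccccc2-c2ccc(CN3C[C@@H](C)N[C@@H](C)C3)cc2)on1`) keeps the shared core and differs from compound 2 in one place: 3-methyl-1,2-oxazol-5-yl in place of phenylsulfonyl on a saturated chain carbon bound to a carbonyl carbon. In words, 3-methyl-1,2-oxazol-5-yl stands in place of phenylsulfonyl on a saturated chain carbon bound to a carbonyl carbon.

Going by the values given here, only one measured step bears on this place: a 2.2-fold lower number from compound 1 to compound 2 (0.34 log units; beyond the scatter) when phenylsulfonyl replaced phenoxy. That step is modest but beyond the scatter. Among the compounds with values here, it shows that a change here can move the number, though no measured compound carries the entering group. Compound 2 holds the lower number of the pair, so a small rise is the more likely direction, no larger than the measured step.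

The expected change is a 1.4-fold higher number from compound 2 to compound 3 (0.14 log units; within the scatter) in this assay and may stay within the scatter. For compound 3 the estimated value is 6 mL.min-1.g-1 with an expected range of 2.5 mL.min-1.g-1 to 14 mL.min-1.g-1 as the working figures.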

Compound 3, intrinsic clearance in microsomes: 2.9 mL.min-1.g-1
Estimate against measurement, compound 3: 2.1-fold (0.32 log units) above; measured number inside the range.
By their numbers in this assay, from the lowest: compounds 3 and 2 (each within the scatter of the next); then compound 1.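

In this assay, the place on a saturated chain carbon bound to a carbonyl carbon now carries three groups, and the step of a 1.5-fold lower number from compound 2 to compound 3 (0.17 log units; within the scatter) shows that the sulfur-bearing phenylsulfonyl group can give way to 3-methyl-1,2-oxazol-5-yl, with 6 heavy atoms instead of 9 and a five-membered aromatic ring instead of a six-membered one, without a change that can be read. The step of a 3.3-fold lower number from compound 1 to compound 3 (0.52 log units; beyond the scatter) shows that the difference from phenoxy is not confined to phenylsulfonyl, so among these three compounds phenoxy stands apart from the two other groups. No data shown here explain either step or why these two groups read alike.

On these data alone, it remains open whether an aromatic ring is needed at this place at all, which a dimethylamino group, a carboxylic acid or a plain methyl on the same chain carbon would address. Also open, as far as these compounds go, are the part played by the methyl on 3-methyl-1,2-oxazol-5-yl, which the unsubstituted 1,2-oxazol-5-yl would address, and the effect of a longer chain carrying the same ring.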